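Cytotoxicity notes: 3,4-dimethoxyphenyl to 3,4,5-trimethoxyphenyl

The source may hold more compounds than are shown below. What is called first, only, known or untested is meant among the compounds shown, and "the series" means these compounds.

Measured compounds:
- Compound 1 `COC(=O)c1cc(-c2cccc(NC(=O)c3ccc(/C=C/C(=O)c4ccc(OC)cc4OC)cc3)c2)on1`: in an ADME assay on Vero cells (Chlorocebus sabaeus) for cytotoxicity, read by MTT assay, with a stated time of 72 h (a lower number here means that less compound is tolerated, a higher number that more compound is tolerated), compound 1 gives > 50 ug/mL, a limit only.
- Compound 2 `COC(=O)c1cc(-c2cccc(NC(=O)c3ccc(/C=C/C(=O)c4ccc(CC(C)C)cc4)cc3)c2)on1`: in this assay compound 2 gives > 10 ug/mL, again a limit.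
- Compound 3 `COC(=O)c1cc(-c2cccc(NC(=O)c3ccc(/C=C/C(=O)c4ccc(OC)c(OC)c4)cc3)c2)on1`: in this assay compound 3 gives > 50 ug/mL, also a limit.

Compound 3 thus sits at the limit of > 50 ug/mL in this assay, at which 2 of the 3 values shown sit, while one value sits at the limit of > 10 ug/mL in this assay, at which 1 of the 3 values shown sits. No number stands for any of the three. The steps bearing on compound 3 are a step that the two limits leave unreadable from compound 1 to compound 3 and a step that the two limits leave unreadable from compound 2 to compound 3; both are bracketed by limits and give no size.

Compound 4 `COC(=O)c1cc(-c2cccc(NC(=O)c3ccc(/C=C/C(=O)c4cc(OC)c(OC)c(OC)c4)cc3)c2)on1` differs from compound 3 by methoxy in place of hydrogen on an aromatic carbon. With every measured value a limit, the step is expected to be none beyond the scatter, a step that the limit leaves unreadable from compound 3 to compound 4. Compound 4 is accordingly estimated at 60 ug/mL, range 25 ug/mL to 150 ug/mL, most probably reported again only as a limit.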

Compound 4, half-maximal cytotoxic concentration: > 50 ug/mL
Compound 4 ended at the assay's limit; the forecaster's own chance of this, stated with the estimate: 75%; the middle value does not contradict the limit.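

In this assay, among these compounds, compound 4 gives > 50 ug/mL, a limit, and no step from compound 1, compound 2 or compound 3 to compound 4 can be read. Going by these compounds, whether changing the substituted phenyl on the carbonyl carbon shifts the cytotoxic concentration at all remains open; all four compounds carry limits only.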